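The source may hold more compounds than are shown below. What is called first, only, known or untested is meant among the compounds shown, and "the series" means these compounds.

Values measured so far in a functional assay on A549 cells (Homo sapiens) for antiproliferative activity, read by MTT assay, with a stated time of 48 h; a higher number here means a weaker inhibitor, a lower number a stronger inhibitor 
- compound 1 `CC(C)=CCC[C@]1(C)/C=C/[C@@H](OC(=O)C=C(C)C)[C@](C)(O)/C=C/C(=O)/C(C[Si](c2ccccc2)(c2ccccc2)C(C)(C)C)=C\C1` gives 13000 nM 
- compound 2 `CSC(=S)OC/C1=C/C[C@](C)(CCC=C(C)C)/C=C/[C@@H](OC(=O)C=C(C)C)[C@](C)(O)/C=C/C1=O` gives 380 nM 
- compound 3 `CC(=O)O[C@@H]1/C=C/[C@@](C)(CCC=C(C)C)C/C=C(/CO)C(=O)/C=C/[C@@]1(C)O` gives 8670 nM 

Compound 3 at 8670 nM lies within the usual scatter of compound 1 at 13000 nM and well away from compound 2 at 380 nM on the stronger side. So compound 3 is a weak starting point, and there is clear room for improvement.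

The next compound, compound 4 `CC(C)=CCC[C@]1(C)/C=C/[C@@H](OC(=O)c2ccccc2)[C@](C)(O)/C=C/C(=O)/C(CO)=C\C1`, changes compound 3 in one place: phenyl in place of methyl on a carbonyl carbon. This puts phenyl in place of methyl on a carbonyl carbon, which turns acetoxy to benzoyloxy.

Among the measured compounds shown here, no two measured compounds differ in one place only, so nothing measured so far shows the size of this change directly. Compound 1 and compound 2 share an ester that is not acetoxy, yet their values lie far apart, so the ester gives little guidance. The expectation in this assay is therefore a small shift towards a lower number, with nothing beyond the scatter. The step expected is a 1.7-fold lower number from compound 3 to compound 4 (0.24 log units; within the scatter) on this reasoning. Compound 4 is estimated at 5000 nM with an expected range from 1500 nM to 15000 nM in this assay.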

Compound 4, half-maximal inhibitory concentration: 15800 nM
Estimate against measurement, compound 4: 3.2-fold (0.50 log units) below; the measured number lies above the stated range.
By their numbers in this assay, from the lowest: compound 2; then compounds 3, 1 and 4 (each within the scatter of the next).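

In this assay, among the compounds shown here, this is the first pair that differs in one place only, and it gives a 1.8-fold higher number from compound 3 to compound 4 (0.26 log units; within the scatter). For the compounds shown here, replacing methyl with phenyl on this carbonyl carbon, which turns acetoxy into benzoyloxy, adds a six-membered aromatic ring, yet the two compounds cannot be told apart within the scatter, something the earlier compounds could not show because none formed such a pair. No measurement shown here explains why the larger group makes so little visible difference in this assay.

From the compounds shown here alone, it remains open whether any other group at this place would move the number beyond the scatter, for example a longer chain, an acyl group carrying an amine, or one carrying a carboxylic acid. This single pair also cannot show whether phenyl and methyl would compare in the same way on a carbonyl carbon elsewhere in the shared core, so it supports no general rule about this change.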